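Swapping the para-bromo for fluoro on the aryl of compound 3

The source may hold more compounds than are shown below. What is called first, only, known or untested is meant among the compounds shown, and "the series" means these compounds.

The three measured compounds share one core and differ only in the group on one aromatic carbon. Compound 1 `CCc1nc2sccn2c1/C=N/OCc1ccc(Cl)c(Cl)c1` carries ethyl there and gives 2600 nM in an assay on HepG2 cells for agonist activity at nuclear receptor subfamily 1 group I member 3 (Homo sapiens), read by a luciferase reporter, with a stated time of 23 h; a lower number here means that less compound is needed, a higher number that more compound is needed for the effect. Compound 2 `N#Cc1ccc(-c2nc3sccn3c2/C=N/OCc2ccc(Cl)c(Cl)c2)cc1` carries 4-cyanophenyl and gives 3400 nM. Compound 3 `Clc1ccc(CO/N=C/c2c(-c3ccc(Br)cc3)nc3sccn23)cc1Cl` carries 4-bromophenyl and gives 480 nM, the lowest number of the three; its neighbours stand a 5.4-fold lower number from compound 1 to compound 3 (0.73 log units; beyond the scatter) and a 7.1-fold lower number from compound 2 to compound 3 (0.85 log units; beyond the scatter) away, both beyond the scatter, so compound 3 is the most potent measured compound. Compound 4 `Fc1ccc(-c2nc3sccn3c2/C=N/OCc2ccc(Cl)c(Cl)c2)cc1` differs from compound 3 by fluoro in place of bromo on an aromatic carbon. Among the measured compounds shown here, no measured step exchanges one halogen for another; the nearest bearing is the step of a 7.1-fold lower number from compound 2 to compound 3 (0.85 log units; beyond the scatter), which shows that the group at this position can move the number beyond the scatter. With fluoro in place of bromo, compound 4 is expected to give a 2.5-fold higher number from compound 3 to compound 4 (0.40 log units; beyond the scatter), a modest rise in the number. The estimate for compound 4 is therefore 1200 nM, with a range from 400 nM to 3500 nM.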

Compound 4, half-maximal effective concentration: 670 nM
For compound 4 the middle estimate is 1.8-fold (0.25 log units) above the measured one; the measured number falls inside the stated range.
By their numbers in this assay, from the lowest: compounds 3 and 4 (each within the scatter of the next); then compounds 1 and 2 (each within the scatter of the next).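

Fluoro in place of bromo is the first exchange of one halogen for another at this position, and in this assay it gives a 1.4-fold higher number from compound 3 to compound 4 (0.14 log units; within the scatter), so the two halogens cannot be told apart here. Compound 4 also stands clear of the other two measured compounds, with a 5.1-fold lower number from compound 2 to compound 4 (0.71 log units; beyond the scatter) and a 3.9-fold lower number from compound 1 to compound 4 (0.59 log units; beyond the scatter), so the lower number is not confined to the 4-bromophenyl group but is shared by both 4-halophenyl compounds, while compound 2, with its 4-cyanophenyl group, goes against any reading that a substituted phenyl ring alone is enough. Nothing available explains why the two halogens read alike. As far as these compounds go, it remains open whether the lower number would hold with a methoxy group or an amine in place of the halogen. The plain phenyl ring, without any group on it, also remains to be placed against these compounds.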